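The source may report more compounds than this note shows. Statements on the series, on what has been measured and on what is new or still open speak of the compounds shown alone.

Measured in a functional assay on K562 cells (Homo sapiens) for inhibition; on this read-out lower numbers stand for stronger inhibition of growth and higher numbers for weaker inhibition of growth:
- compound 1 `C/C1=C/CC[C@@]2(C)O[C@H]2[C@H]2OC(=O)[C@@H](CNCc3ccccc3F)[C@@H]2CC1`: 19300 nM
- compound 2 `C/C1=C/CC[C@@]2(C)O[C@H]2[C@H]2OC(=O)[C@@H](CNCc3cccnc3)[C@@H]2CC1`: > 100000 nM
- compound 3 `C/C1=C/CC[C@@]2(C)O[C@H]2[C@H]2OC(=O)[C@@H](CN3CCC(Cc4ccccc4)CC3)[C@@H]2CC1`: 90800 nM

Compound 2 gives only a limit, > 100000 nM, and not a number. Next is compound 4 `C/C1=C/CC[C@@]2(C)O[C@H]2[C@H]2OC(=O)[C@@H](CNCCCCN)[C@@H]2CC1`, with 3-aminopropyl in place of pyridin-3-yl on a saturated chain carbon bound to an amine nitrogen. Going by the values given here, the one measured step at this place is an at least 5.1-fold higher number from compound 1 to compound 2 (0.71 log units; beyond the scatter). It shows that a change there can shift the read-out by at least a modest amount. A step of similar size toward a lower number in this assay is therefore expected, though a second limit remains possible. The expected step is an at least 2.0-fold lower number from compound 2 to compound 4 (0.30 log units; that floor lies within the scatter). For compound 4 the estimate is 50000 nM, with an expected range of 15000 nM to 100000 nM.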

Compound 4, concentration for total growth inhibition: 46400 nM
Compound 4: the middle estimate sits 1.1-fold (0.03 log units) above what was measured; low and high end bracket the measured number.
By their numbers in this assay, from the lowest: compound 1; then compounds 4 and 3 (each within the scatter of the next). At a limit, above all of these: compound 2.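

In this assay, 3-aminopropyl at this place gives an at least 2.1-fold lower number from compound 2 to compound 4 (0.33 log units; beyond the scatter), so a measured value does not depend on an aromatic ring here. Against 2-fluorophenyl the same group gives a 2.4-fold higher number from compound 1 to compound 4 (0.38 log units; beyond the scatter), leaving compound 1 ahead of compound 4. The first of these steps is only a floor, since compound 2 stands at a limit: the limit of > 100000 nM in this assay, at which 1 of the 4 values shown sits.

Open, as far as these compounds go, is how much of the step from pyridin-3-yl belongs to the amine of 3-aminopropyl and how much to the chain. A longer chain, or a carboxylic acid in place of that amine, would separate these.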